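Aryl group replaces cyclohexylpiperazine on the anilide core

This account rests on a few compounds, and the source may have more. Where it says the series, first, only, none or still open, it means among the compounds named here.

Measured so far:
compound 1 `CC(C(=O)NCc1ccc(C(F)(F)F)cc1N1CCN(C2CCCCC2)CC1)c1ccc(NS(C)(=O)=O)c(F)c1` — 13.8 nM
compound 2 `C[C@H](C(=O)NCc1ccc(C(F)(F)F)cc1SC1CCCCC1)c1ccc(NS(C)(=O)=O)c(F)c1` — 0.3 nM

In an assay on CHO cells for antagonist activity at transient receptor potential cation channel subfamily V member 1 (Homo sapiens), read by FLIPR (a lower number here means a stronger inhibitor, a higher number a weaker inhibitor), compound 1 gives the higher of the two numbers; compound 2, differing at several places, gives 0.3 nM, a gap well beyond the scatter. Compound 3 `CC(C(=O)NCc1ccc(C(F)(F)F)cc1-c1cccc(F)c1)c1ccc(NS(C)(=O)=O)c(F)c1` is not yet measured. It differs from compound 1 by 3-fluorophenyl in place of 4-cyclohexylpiperazin-1-yl on an aromatic carbon. For the measured compounds named here, no measured pair isolates this change. Given that the only other compound, compound 2, lies far lower at 0.3 nM, the step of a 2.8-fold lower number from compound 1 to compound 3 (0.44 log units; beyond the scatter) is expected to lower the number by a moderate margin, beyond the scatter. Compound 3 is therefore estimated at 5 nM, within 1 nM to 30 nM.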

Compound 3, inhibition constant: 1.9 nM
Beside the measured number, compound 3's estimate is 2.6-fold (0.42 log units) above it; measured number inside the range.
By their numbers in this assay, from the lowest: compound 2; then compound 3; then compound 1.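

In this assay, the aromatic carbon meta to the trifluoromethyl group shows a 7.3-fold lower number from compound 1 to compound 3 (0.86 log units; beyond the scatter) when 3-fluorophenyl replaces 4-cyclohexylpiperazin-1-yl. The position therefore accepts a directly attached aromatic ring of carbon only, with fewer heavy atoms and no hydrogen-bond acceptors, and the piperazine ring is not required for a low number. No measurement available here bears on the reason for this step. Still open, as far as these compounds go, is whether the fluorine contributes, which unsubstituted phenyl would test, and how a pyridine ring or a 3-methoxyphenyl group would compare at this carbon.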